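Series notes: chain variation on the shared core

The source may report more compounds than this note shows. Statements on the series, on what has been measured and on what is new or still open speak of the compounds shown alone.

Measured so far:
- compound 1 `CCCCCc1cc(C(C)=O)c(O)cc1OCCCCC#N`: 31%
- compound 2 `CCc1cc(C(C)=O)c(O)cc1OCCCCCCC(C)(C)C#N`: 65%
- compound 3 `C=CCc1cc(C(C)=O)c(O)cc1OCCCCCCC`: 31%

In an assay on isolated protein for inhibition of leukotriene B4 receptor 1 (Homo sapiens), tested at 10 uM (on this read-out higher numbers stand for more inhibition at the one concentration tested (going by the name of the read-out) and lower numbers for less inhibition), compound 2 stands highest of the three; compound 1 and compound 3 both sit a step below it that lies beyond the scatter. Among the measured compounds shown here, no pair of these three differs in one place only, so no single step is isolated.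

Compound 4 `CCc1cc(C(C)=O)c(O)cc1OCCCCCC[S+](C)[O-]` is the next to be tested in this assay. Relative to compound 2 the change is a group of 3 heavy atoms (1 carbon, 1 oxygen, 1 sulfur; no ring) in place of a group of 5 heavy atoms (4 carbon, 1 nitrogen; no ring), on a saturated chain carbon, six bonds along the chain from an oxygen on an aromatic ring. For the measured compounds named here, nothing measured so far covers this change. Given that compound 2 gives 65% and the nitrile-bearing compound 1 gives 31%, a drop from compound 2 to compound 4 of about a number 25 percentage points lower from compound 2 to compound 4 (beyond the scatter) is expected. Compound 4 is estimated at 40%, within 15% to 65%.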

Compound 4, a percentage reported as inhibition, at one concentration (the size of the read-out at that concentration, not a potency): 92%
Compound 4: the middle estimate sits 52 percentage points below what was measured; the whole stated range lies below it.
By their numbers in this assay, from the lowest: compounds 1 and 3 (each within the scatter of the next); then compound 2; then compound 4.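

In this assay, replacing the 1-cyano-1-methylethyl group with a group of 3 heavy atoms (1 carbon, 1 oxygen, 1 sulfur) at this place gives a number 27 percentage points higher from compound 2 to compound 4 (beyond the scatter). Among the compounds shown here, this is the first single change isolated, and it shows that a nitrile is not required on this saturated chain carbon and that the smaller group does not cost inhibition. No measurement at hand bears on what lies behind the step.

Open, from the compounds shown here alone, is whether an amine or a carboxylic acid in the same place would reach a similar level. Going by these compounds, whether the step carries over to the other chains of compound 1 and compound 3 also stays open.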